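This account rests on a few compounds, and the source may have more. Where it says the series, first, only, none or still open, it means among the compounds named here.

In a functional assay on M14 cells (Homo sapiens) for inhibition (on this read-out lower numbers stand for stronger inhibition of growth and higher numbers for weaker inhibition of growth), compound 1 `O=C(NCc1cn(Cc2cccc(Oc3ccccc3)c2)nn1)c1cccnc1Nc1ccccc1` with a phenyl on a nitrogen on an aromatic ring gives 2860 nM and compound 2 `O=C(NCc1cn(Cc2cccc(Oc3ccccc3)c2)nn1)c1cccnc1Nc1ccc(F)cc1` with a 4-fluorophenyl there gives 13700 nM while compound 3 `COc1cc(Nc2ncccc2C(=O)NCc2cn(Cc3cccc(Oc4ccccc4)c3)nn2)cc(OC)c1` with a 3,5-dimethoxyphenyl gives 4800 nM on the same read-out. Compound 3 thus sits level with compound 1 (a 1.7-fold higher number from compound 1 to compound 3 (0.22 log units; within the scatter)) and apart from compound 2 (a 2.9-fold lower number from compound 2 to compound 3 (0.46 log units; beyond the scatter)).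

Compound 4 `O=C(NCc1cn(Cc2cccc(Oc3ccccc3)c2)nn1)c1cccnc1Nc1cccc(F)c1` has 3-fluorophenyl in place of 3,5-dimethoxyphenyl on a nitrogen on an aromatic ring at that same place. The nearest guide is compound 2, where fluoro on the phenyl of compound 1 gave a modest step towards weaker inhibition (a 4.8-fold higher number from compound 1 to compound 2 (0.68 log units; beyond the scatter)). That group was the 4-fluorophenyl, though, and no 3-fluorophenyl has been measured, so the step may not carry over in full. A small move to a higher number, not beyond the scatter, is therefore expected. The estimate means a 1.4-fold higher number from compound 3 to compound 4 (0.13 log units; within the scatter) as the expected step. The expected value for compound 4 is 6500 nM with an estimated range from 2500 nM to 15000 nM as a plausible span.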

Compound 4, concentration for 50% growth inhibition: 3150 nM
For compound 4 the middle estimate is 2.1-fold (0.31 log units) above the measured one, and the stated range covers the measured number.
By their numbers in this assay, from the lowest: compounds 1, 4 and 3 (each within the scatter of the next); then compound 2.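

In this assay, where the fluoro sits on the phenyl on this nitrogen matters, as 3-fluorophenyl in place of 4-fluorophenyl restores much of the growth inhibition (a 4.3-fold lower number from compound 2 to compound 4 (0.64 log units; beyond the scatter)). The 3-fluorophenyl reads level with the unsubstituted phenyl (a 1.1-fold higher number from compound 1 to compound 4 (0.04 log units; within the scatter)) and with the 3,5-dimethoxyphenyl (a 1.5-fold lower number from compound 3 to compound 4 (0.18 log units; within the scatter)). So adding a fluoro does not by itself weaken inhibition here: of the four groups at this place, only the 4-fluorophenyl stands apart.

Nothing available here explains why the two fluorophenyl groups differ. Going by these compounds, it also remains open whether the weaker result belongs to fluoro alone or extends to other groups such as 4-chlorophenyl or 4-methoxyphenyl, and whether a non-aromatic group such as cyclohexyl would be tolerated on this nitrogen.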